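Swapping methoxy for fluoro on the anilide ring

A few compounds are considered here, and "the series" means these few. Any claim that something is new, unique, unknown or untested is made for them only; others in the source may bear on it.

Compound 1, `COc1ccc(Nc2ccc(N3CC4CC(C3)N4)nn2)cc1`, is the weaker of the two measured compounds in an assay on cell membranes for displacement of a labelled ligand from Neuronal acetylcholine receptor; alpha4/beta2 (Rattus norvegicus); a lower number here means a stronger inhibitor, a higher number a weaker inhibitor: compound 1 gives 578 nM, while compound 2, `Oc1ccc(Nc2cncc(N3CC4CC(C3)N4)c2)cc1`, built on a different core, gives 0.342 nM. Compound 3, `Fc1ccc(Nc2ccc(N3CC4CC(C3)N4)nn2)cc1`, keeps the core of compound 1 and changes one group: fluoro in place of methoxy on an aromatic carbon. Going by the values given here, no measured pair shows this exact change, so the step from compound 1 to compound 3 is expected to be small, a 1.1-fold higher number from compound 1 to compound 3 (0.05 log units; within the scatter), not clearly beyond the scatter in either direction. Compound 3 is therefore estimated at 650 nM, with a range from 150 nM to 2800 nM.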

Compound 3, inhibition constant: 868 nM
For compound 3 the middle estimate is 1.3-fold (0.13 log units) below the measured one; the measured number falls inside the stated range.
By their numbers in this assay, from the lowest: compound 2; then compounds 1 and 3 (each within the scatter of the next).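

In this assay, fluoro in place of methoxy on the aromatic carbon para to a large group gives a 1.5-fold higher number from compound 1 to compound 3 (0.18 log units; within the scatter), so this pair cannot be told apart. On the core of compound 1, the hydrogen-bond acceptor and the larger methoxy group can therefore give way to a single fluorine with no shift beyond the scatter. Nothing available here offers a reason for this result.

From the compounds shown here alone, whether any group at this position can move the number beyond the scatter stays open. An amine or a carboxylic acid there would test this.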